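Swapping a hydroxybutyl tail for a methoxyphenyl group

The source may hold more compounds than are shown below. What is called first, only, known or untested is meant among the compounds shown, and "the series" means these compounds.

Measured so far:
Compound 1, `OCCNCc1nc2c(OCC3CCCCC3)cccc2[nH]1`: 20000 nM
Compound 2, `OCCCCNCc1nc2c(OCC3CCCCC3)cccc2[nH]1`: 30000 nM

Both compounds were tested in an assay on cells for inhibition of interleukin-5 receptor subunit alpha (Mus musculus), read by WST assay, with a stated time of 48 h, in the presence of a further agent that is not named here; a higher number here means a weaker inhibitor, a lower number a stronger inhibitor. Among the measured compounds shown here, compound 2 has the highest of the two numbers, but its only neighbour is compound 1, and the step of a 1.5-fold higher number from compound 1 to compound 2 (0.18 log units; within the scatter) is too small to count as a real difference, so the two compounds sit level. Compound 3, `COc1ccc(NCc2nc3c(OCC4CCCCC4)cccc3[nH]2)cc1`, has not been measured yet. It differs from compound 2 in one place: 4-methoxyphenyl in place of 4-hydroxybutyl on an amine nitrogen. For the measured compounds named here, the only measured step, from compound 1 to compound 2, concerns lengthening the hydroxy-bearing chain and says nothing about exchanging that chain for an aromatic group, so no measured step bears on this change. With both known values weak and close together, the best guess is that compound 3 stays in the same weak region; its expected step of a 1.5-fold lower number from compound 2 to compound 3 (0.18 log units; within the scatter) is small. Compound 3 is therefore estimated at 20000 nM, expected to lie between 4000 nM and 60000 nM.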

Compound 3, half-maximal inhibitory concentration: > 30000 nM
Compound 3: a limit, no number (the forecaster's own chance of this, stated with the estimate: 30%); middle value at least 1.5-fold (0.17 log units) from the limit.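

In this assay compound 3 gives > 30000 nM as a limit of the assay and not a number, and the reading stops there for this compound alone: the limit of > 30000 nM in this assay, at which 1 of the 3 values shown sits. On this amine nitrogen, then, 4-methoxyphenyl in place of the 4-hydroxybutyl chain brings a number no lower from compound 2 to compound 3 (the limit leaves the size open), so the earlier finding of weak inhibition now extends from two hydroxy-bearing chains to a chain-free aromatic group. The comparison with the shorter chain gives an at least 1.5-fold higher number from compound 1 to compound 3 (0.17 log units; that floor lies within the scatter) as its only readable result, so no real separation is shown there.

Going by these compounds, how far compound 3 lies beyond its limit stays open, and so does whether the methoxy group or the aromatic ring itself accounts for that reading. Also open, on these data alone, is whether a plain phenyl, a benzyl, an amine-bearing chain or a carboxylic acid on this nitrogen would bring the number down into a clearly stronger range.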